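Cytotoxicity limits across the pyrrolidinone series

This account rests on a few compounds, and the source may have more. Where it says the series, first, only, none or still open, it means among the compounds named here.

Measured compounds:
Compound 1 `COc1ccc([C@H]2CC(=O)N(c3cc(N)cc(N)c3)C2)cc1OC1CCCC1`: in a functional assay on HEK293 cells (Homo sapiens) for cytotoxicity (a higher number here means that more compound is tolerated, a lower number that less compound is tolerated), compound 1 gives > 10000 nM, a limit of the assay.
Compound 2 `COc1ccc([C@H]2CC(=O)N(c3ccccc3C)C2)cc1OC1CCCC1`: in this assay compound 2 gives > 10000 nM, a limit of the assay.
Compound 3 `CCCCNc1cccc(N2C[C@@H](c3ccc(OC)c(OC4CCCC4)c3)CC2=O)c1`: in this assay compound 3 gives > 10000 nM, a limit of the assay.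

Compound 3 thus stands at the limit, and every value shown sits there, as the limit of > 10000 nM in this assay, at which 3 of the 3 values shown sit, records. Among the compounds with values here, the only comparison between measured compounds, a step that the two limits leave unreadable from compound 1 to compound 2, is one that the two limits leave unreadable, so no step size is available.

Compound 4 `COc1ccc([C@H]2CC(=O)N(c3cccc(NS(=O)(=O)c4ccccc4C)c3)C2)cc1OC1CCCC1` differs from compound 3 by (2-methylphenyl)sulfonyl in place of butyl on a nitrogen on an aromatic ring. Within the data shown here, no measured step bears on this change, and the series gives no readable step anywhere in this assay. The expectation therefore rests only on the shared core of compounds 1, 2 and 3 and on the limit at which all of them sit: a further limit, with no movement beyond the scatter, is expected for compound 4, meaning an expected step of a number no higher from compound 3 to compound 4 (the limit leaves the size open). The estimate for compound 4 is 10000 nM, expected to fall between 3000 nM and 30000 nM.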

Compound 4, half-maximal cytotoxic concentration: > 10000 nM
Compound 4: no number, only a limit; the forecaster's own chance of this, stated with the estimate: 80%; the middle value lies on the limit itself.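

The step between compound 3 and compound 4 cannot be read, because both compounds sit at the same limit: the limit of > 10000 nM in this assay, at which 4 of the 4 values shown sit.

The compounds shown leave open at what concentration any of them becomes cytotoxic in this assay, and whether any change on the shared core shifts that concentration.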